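Dimethylamino on the aniline ring of a pyridylpyrimidine

The compounds below may be only part of what the source reports. "The series", "measured", "known", "first", "only" and "open" are said of these compounds alone.

Compound 1 `CN(c1ccccc1)c1nccc(-c2ccncc2)n1`: > 24000 nM in a functional assay for inhibition, with Homo sapiens as the target; a lower number here means a stronger inhibitor, a higher number a weaker inhibitor (a limit of the assay, not a number)
Compound 2 `c1ccc(Nc2nccc(-c3ccncc3)n2)cc1`: 900 nM in this assay
Compound 3 `Cc1ccccc1Nc1nccc(-c2ccncc2)n1`: 3900 nM in this assay

Compound 2 gives the lowest of the two numbers in this assay. Compound 3 gives a higher number, and the step of a 4.3-fold higher number from compound 2 to compound 3 (0.64 log units; beyond the scatter) lies beyond the scatter. Compound 1 gives only a limit in this assay (the limit of > 24000 nM in this assay, at which 1 of the 3 values shown sits), and the step of an at least 26-fold lower number from compound 1 to compound 2 (1.42 log units; beyond the scatter) shows how far the measured value of compound 2 lies from that limit.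

Compound 4 `CN(C)c1cccc(Nc2nccc(-c3ccncc3)n2)c1` differs from compound 2 in one place: dimethylamino in place of hydrogen on an aromatic carbon. The step that bears most on it is the change from compound 2 to compound 3, where a methyl on an aromatic carbon of the same ring made the number higher by a modest amount. The step from compound 1 to compound 2 concerns a nitrogen on an aromatic ring and speaks less directly to the new group. A modest rise in the number, or none beyond the scatter, is therefore expected, as a 1.7-fold higher number from compound 2 to compound 4 (0.22 log units; within the scatter). The estimate for compound 4 in this assay is 1500 nM, expected to fall between 400 nM and 6000 nM.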

Compound 4, half-maximal inhibitory concentration: 3700 nM
Compound 4: middle estimate off by 2.5-fold (0.39 log units), on the low side; the measured number falls inside the stated range.
By their numbers in this assay, from the lowest: compound 2; then compounds 4 and 3 (each within the scatter of the next). At a limit, above all of these: compound 1.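

Among the compounds shown here, the result extends what the earlier compounds showed: a methyl was the only group they showed on an aromatic carbon of this ring, and now a larger dimethylamino group, placed on an aromatic carbon meta to a large group, also moves the number in this assay away from that of the unsubstituted compound, with a 4.1-fold higher number from compound 2 to compound 4 (0.61 log units; beyond the scatter). This rise lies beyond the scatter, so this position does not accept the new group without a loss, and none of the substituted compounds shown improves on compound 2, which keeps the lowest number of the series. Nothing shown here accounts for the rise, and no measured property of the dimethylamino group or of this position bears on it.

The compounds shown leave open whether the loss belongs to this position or to the dimethylamino group itself, since a single group at this place cannot separate the two. A primary amine, a methoxy group or a carboxylic acid on the same carbon, or dimethylamino on another carbon of the ring, would bear on that question in this assay.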